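Swapping pyridin-4-yl for phenyl on a shared core

A few compounds are considered here, and "the series" means these few. Any claim that something is new, unique, unknown or untested is made for them only; others in the source may bear on it.

compound 1 `Nc1nc(-c2ccccn2)nn1-c1ncnc2cc(OC(F)(F)F)ccc12` gives > 13000 nM as a limit
compound 2 `COc1cc2ncnc(-n3nc(-c4cccnc4)nc3N)c2cc1OC` gives > 71000 nM as a limit
compound 3 `COc1cc2ncnc(-n3nc(-c4ccncc4)nc3N)c2cc1OC` gives "not determined" (no result reported) and so no result

These entries all come from an ADME assay on BJ cells (Homo sapiens) for cytotoxicity, with a stated time of 72 h (on this read-out higher numbers stand for an effect only at larger amounts of compound and lower numbers for an effect already at smaller amounts), and none of them is an exact number. Compound 1 has only a limit, at > 13000 nM in this test. Compound 2 likewise has only a limit, at > 71000 nM on the same scale. Compound 3 has no place on this scale, because its entry reads "not determined" (no result reported) and no result was reported.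

The next compound to be tested is compound 4 `COc1cc2ncnc(-n3nc(-c4ccccc4)nc3N)c2cc1OC`, which has not yet been measured. Its structure differs from that of compound 3 in one place (phenyl in place of pyridin-4-yl on an aromatic carbon), with phenyl in place of pyridin-4-yl on an aromatic carbon of the five-membered ring.

Among the measured compounds shown here, no measured step shows what such a swap does. Leaning on the limit of compound 2 at > 71000 nM, the expectation for compound 4 is an effect only at large amounts, with no step beyond the usual scatter and no clear direction in this assay for now. For compound 4 the estimated value is 50000 nM, with an expected range from 13000 nM to 100000 nM and a good chance that only a limit is reported.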

Compound 4, half-maximal effective concentration: > 50000 nM
Compound 4 ended at the assay's limit (the forecaster's own chance of this, stated with the estimate: 75%); the middle value lies on the limit itself.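

Compound 2 and compound 4 each have only a limit in this assay, so no step can be read from one to the other. The compounds shown leave open what phenyl in place of pyridin-3-yl or pyridin-4-yl does to the amount of compound needed for an effect on these cells.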